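This account rests on a few compounds, and the source may have more. Where it says the series, first, only, none or still open, it means among the compounds named here.

Measured so far:
Compound 1 `CCc1nc2sccn2c1/C=N/OCc1ccc(Cl)c(Cl)c1`: 2600 nM
Compound 2 `C(=N/OCc1ccccc1)\c1c(-c2ccc3ccccc3c2)nc2occn12`: 840 nM

In an assay on HepG2 cells for agonist activity at nuclear receptor subfamily 1 group I member 3 (Homo sapiens), read by a luciferase reporter, with a stated time of 23 h (on this read-out lower numbers stand for an effect already at smaller amounts and higher numbers for an effect only at larger amounts of compound), compound 1 gives 2600 nM, the higher of the two numbers recorded. Compound 2 differs from compound 1 in several places; in this assay compound 2 gives 840 nM, a lower number by a margin that lies beyond the usual scatter. Compound 3 `COc1ccc(-c2nc3sccn3c2/C=N/OCc2ccc(Cl)c(Cl)c2)cc1` has not yet been measured. It differs from compound 1 by 4-methoxyphenyl in place of ethyl on an aromatic carbon. Within the data shown here, no pair of measured compounds that differ in this one place exists, so the effect of the change is not known directly, and compound 2 cannot serve as a clean guide. A modest step toward lower numbers is nevertheless expected, a 2.6-fold lower number from compound 1 to compound 3 (0.41 log units; beyond the scatter), though it may remain within the scatter. Compound 3 is thus estimated at about 1000 nM, in a range from 300 nM to 3500 nM.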

Compound 3, half-maximal effective concentration: 490 nM
Beside the measured number, compound 3's estimate is 2.0-fold (0.31 log units) above it; low and high end bracket the measured number.
By their numbers in this assay, from the lowest: compounds 3 and 2 (each within the scatter of the next); then compound 1.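

In this assay, among these compounds, 4-methoxyphenyl in place of ethyl on this aromatic carbon gives a 5.3-fold lower number from compound 1 to compound 3 (0.72 log units; beyond the scatter) with the rest of the structure unchanged, the first direct reading of a change at this position. It shows that this carbon of the five-membered aromatic ring with 2 nitrogen can carry a group of 8 heavy atoms with a six-membered aromatic ring in place of one of 2 heavy atoms, and that the number falls rather than rises. Nothing available explains this step.

The compounds shown leave open whether the aromatic ring alone accounts for the step or the methoxy group also contributes, as plain phenyl is not among them. Nor do they tell whether a longer chain such as butyl would lower the number without any ring.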